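4-Aminocyclohexyl to 3-hydroxycyclopentyl: estimating a half-life

The source may hold more compounds than are shown below. What is called first, only, known or untested is meant among the compounds shown, and "the series" means these compounds.

In an ADME assay on microsomes from liver (Homo sapiens) for metabolic stability, read by LC-MS, using NADPH, with a stated time of 10 min, tested at 10 uM (on this read-out higher numbers stand for a longer-lived compound and lower numbers for a shorter-lived compound), compound 1 `Nc1ncnc2c1c(Oc1cc(C(F)(F)F)ccn1)nn2[C@H]1CC[C@@H](N)CC1` gives > 2.41 h, which is a limit of the assay and not a number. Compound 2 `CC(C)(C)n1nc(Oc2cc(Cl)ccn2)c2c(N)ncnc21` gives a plain number in this assay, 1 h.

The next compound keeps the core of compound 1 and changes one group. Compound 3 `Nc1ncnc2c1c(Oc1cc(C(F)(F)F)ccn1)nn2C1CCC(O)C1` carries 3-hydroxycyclopentyl in place of 4-aminocyclohexyl on an aromatic nitrogen.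

Among the compounds with values here, no measured pair shows this change on its own, so any expectation here is a judgement with wide margins. A small step towards a shorter half-life seems most likely, with no large shift beyond the scatter. The estimated step is an at least 1.3-fold lower number from compound 1 to compound 3 (0.12 log units; that floor lies within the scatter). For compound 3 the expected half-life is 1.8 h, with an estimated range from 0.7 h to 3.5 h.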

Compound 3, half-life: > 2.41 h
Compound 3: a limit, no number (the forecaster's own chance of this, stated with the estimate: 30%); middle value at least 1.3-fold (0.12 log units) away from the limit.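

Within the data shown here, compound 1 and compound 3 each give only a limit in this assay, not a number, so no step between them can be read: the limit of > 2.41 h in this assay, at which 2 of the 3 values shown sit.

The compounds shown leave open whether 3-hydroxycyclopentyl in place of 4-aminocyclohexyl lengthens the half-life, shortens it, or leaves it unchanged.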